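From furan-2-yl to 4-nitrophenyl on a shared core

The compounds below may be only part of what the source reports. "The series", "measured", "known", "first", "only" and "open" are said of these compounds alone.

Within the data shown here, in a functional assay on HT-29 cells (Homo sapiens) for inhibition, with a stated time of 72 h (a higher number here means a weaker inhibitor, a lower number a stronger inhibitor), compound 1 `COc1ccc(S(=O)(=O)N2CCc3cccc(-c4ccc(N)cc4)c32)cc1` gives 301 nM and compound 2 `COc1ccc(S(=O)(=O)N2CCc3cccc(-c4ccco4)c32)cc1` gives 62.5 nM, the lower of the two numbers so far. Compound 3 `COc1ccc(S(=O)(=O)N2CCc3cccc(-c4ccc([N+](=O)[O-])cc4)c32)cc1` has the same core but carries 4-nitrophenyl in place of furan-2-yl on an aromatic carbon. Among the measured compounds shown here, one measured step bears on this change: a 4.8-fold lower number from compound 1 to compound 2 (0.68 log units; beyond the scatter), in which furan-2-yl replaced 4-aminophenyl. For the measured compounds named here, no measurement yet shows how 4-nitrophenyl compares with 4-aminophenyl. Compound 1, at 301 nM, also carries a substituted phenyl group, so a move of similar size back toward a higher number in this assay, meaning a weaker inhibitor, is expected, though one step is thin evidence. The expected step is a 3.5-fold higher number from compound 2 to compound 3 (0.55 log units; beyond the scatter). For compound 3 the estimated value is 220 nM, with an expected range from 70 nM to 700 nM.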

Compound 3, half-maximal inhibitory concentration: 51.8 nM
Compound 3: the middle estimate sits 4.2-fold (0.63 log units) above what was measured; measured number outside the range, below it.
By their numbers in this assay, from the lowest: compounds 3 and 2 (each within the scatter of the next); then compound 1.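

At this position on the shared core, a phenyl ring with a substituent does not by itself go with a higher number in this assay: with a 1.2-fold lower number from compound 2 to compound 3 (0.08 log units; within the scatter), 4-nitrophenyl and furan-2-yl cannot be told apart. The substituent on the phenyl ring does count here, since nitro in place of amino gives a 5.8-fold lower number from compound 1 to compound 3 (0.76 log units; beyond the scatter), a difference that sets compound 1 apart from the other two compounds. No measurement is available to explain why these groups compare as they do.

Going by these compounds, it remains open whether the amino group raises the number or the nitro group lowers it, and a plain phenyl group at this position would help separate those two readings. A thiophene ring in place of furan-2-yl would test whether the result for the furan extends to a related five-membered ring.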